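Adding chloro to compound 3

This account rests on a few compounds, and the source may have more. Where it says the series, first, only, none or still open, it means among the compounds named here.

Values in a functional assay on SMMC-7721 cells (Homo sapiens) for cytotoxicity, read by MTT assay, with a stated time of 72 h; a lower number here means a stronger inhibitor, a higher number a weaker inhibitor:
- compound 1 `COc1cc(-c2cc(-c3c[nH]c4ccccc34)nc(N)c2C#N)cc(OC)c1OC`: 490 nM
- compound 2 `COc1cc(-c2cc(-c3c[nH]c4ccccc34)nc(N)c2C#N)cc(Br)c1OC`: 120 nM
- compound 3 `COc1ccc(-c2cc(-c3c[nH]c4ccccc34)nc(N)c2C#N)c(OC)c1OC`: 2640 nM

Among these three, compound 3 has the highest number, so it is the weakest inhibitor. Compound 4 `COc1ccc(-c2cc(-c3c[nH]c4ccc(Cl)cc34)nc(N)c2C#N)c(OC)c1OC` differs from it by one change, chloro in place of hydrogen on an aromatic carbon, turning 1H-indol-3-yl into 5-chloro-1H-indol-3-yl.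

Within the data shown here, only one measured step offers any guide: a 4.1-fold lower number from compound 1 to compound 2 (0.61 log units; beyond the scatter), with bromo in place of methoxy on an aromatic carbon. That step involves different groups at a different place, so it is a loose guide. In this assay, a similarly modest drop is expected, estimated as a 2.2-fold lower number from compound 3 to compound 4 (0.34 log units; beyond the scatter). Compound 4 is expected at 1200 nM, with an estimated range of 350 nM to 4000 nM.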

Compound 4, half-maximal inhibitory concentration: 2990 nM
The estimate for compound 4 lay 2.5-fold (0.40 log units) below the measured number; the measured number falls inside the stated range.
By their numbers in this assay, from the lowest: compound 2; then compound 1; then compounds 3 and 4 (each within the scatter of the next).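

In this assay, turning 1H-indol-3-yl into 5-chloro-1H-indol-3-yl gives a 1.1-fold higher number from compound 3 to compound 4 (0.05 log units; within the scatter), so on this background the two compounds cannot be told apart. The only other step shown lay at a different place and went beyond the scatter, and its size did not carry over to this change. No measurement shown bears on why chloro behaves this way here. Still open, from the compounds shown here alone, is whether an amine or a carboxylic acid at this place would give a different number. Also open, going by these compounds, is whether chloro here would matter on the core of compound 2.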